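Trading a methoxy-bearing ring for a tert-butyl-bearing ring

A few compounds are considered here, and "the series" means these few. Any claim that something is new, unique, unknown or untested is made for them only; others in the source may bear on it.

In a functional assay on K562 cells (Homo sapiens) for antiproliferative activity, read by MTT assay, with a stated time of 48 h (a lower number here means a stronger inhibitor, a higher number a weaker inhibitor), compound 1 (`COc1ccc(-c2ccc3c(c2)C(=O)C(=O)N3Cc2ccccc2OC)cc1`) gives 40 nM. Compound 2 (`COc1ccc(CN2C(=O)C(=O)c3cc(-c4cccc(OC)c4)ccc32)cc1`) gives 100 nM, the higher of the two numbers and so the weaker result, with a gap beyond the usual scatter. These two compounds differ in more than one place, so they offer no measured effect of a single change to guide the next prediction. Compound 3 (`COc1ccc(CN2C(=O)C(=O)c3cc(-c4ccc(C(C)(C)C)cc4)ccc32)cc1`) keeps the rest of compound 2 but carries 4-(tert-butyl)phenyl in place of 3-methoxyphenyl on an aromatic carbon. Without a direct precedent, this is a judgement rather than a calculation. In this assay a moderate step toward weaker activity is expected, a 2.5-fold higher number from compound 2 to compound 3 (0.40 log units; beyond the scatter). For compound 3 the estimated value is 250 nM, with an expected range of 70 nM to 900 nM.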

Compound 3, half-maximal inhibitory concentration: 2250 nM
The estimate for compound 3 lay 9.0-fold (0.95 log units) below the measured number; the whole stated range lies below it.
By their numbers in this assay, from the lowest: compound 1; then compound 2; then compound 3.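

In this assay, within the data shown here, this position proves highly sensitive to what it carries: 4-(tert-butyl)phenyl in place of 3-methoxyphenyl gives a 23-fold higher number from compound 2 to compound 3 (1.35 log units; beyond the scatter), the first single-change step and a large one. The change does two things at once, replacing a methoxy group with a tert-butyl group and shifting the substituent's place on the phenyl ring, as the names 3-methoxyphenyl and 4-(tert-butyl)phenyl show. No measurement here explains the loss of activity.

This one step cannot separate the identity of the substituent from its place on the phenyl ring, and a 3-(tert-butyl)phenyl group would help to pull those apart. On these data alone, how a phenyl ring carrying an amine or a carboxylic acid would fare at this position also remains open.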